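The compounds below may be only part of what the source reports. "The series", "measured", "known", "first", "only" and "open" are said of these compounds alone.

Compound 1 `CCOc1ccccc1-c1ccc(-c2nc3cnccc3c(N[C@H](CC)C(N)=O)c2C#N)cc1` is the most polar member of a small set that shares one core and varies only in the side chain on the ring nitrogen: in a physicochemical assay for lipophilicity, read by HPLC, at pH 7.5 (a lower number here means a more polar compound, a higher number a more lipophilic compound), compound 1 gives 3, the lowest of the three numbers. Compound 2 `CCCCC(Nc1c(C#N)c(-c2ccc(-c3ccccc3OCC)cc2)nc2cnccc12)C(N)=O` gives 3.6, and compound 3 `CCOc1ccccc1-c1ccc(-c2nc3cnccc3c(N[C@H](CC(C)C)C(N)=O)c2C#N)cc1` gives 3.4. The measured steps of a number 0.60 log units higher from compound 1 to compound 2 (beyond the scatter) and a number 0.40 log units higher from compound 1 to compound 3 (beyond the scatter) both lengthen the chain bearing the amide, while a number 0.20 log units lower from compound 2 to compound 3 (within the scatter) merely reshapes it.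

Compound 4 `CC[C@@H](Nc1c(C#N)c(-c2ccc(-c3ccccc3Cl)cc2)nc2cnccc12)C(N)=O` is a different kind of change: chloro in place of ethoxy on an aromatic carbon. Here the amide side chain is left as in compound 1, and the alteration sits on the outer benzene ring, ortho to a large group. Among the compounds with values here, none of the three measured steps touches that ring, so they say nothing directly about this swap; the only guide is that an ethoxy of three heavy atoms gives way to a single chlorine. For compound 4 a small rise is expected, a number 0.30 log units higher from compound 1 to compound 4 (within the scatter), putting the estimate at 3.3 with a range from 2.9 to 3.7.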

Compound 4, distribution coefficient: 2.9
Estimate against measurement, compound 4: 0.40 log units above; the range from low to high includes it.
By their numbers in this assay, from the lowest: compounds 4 and 1 (each within the scatter of the next); then compounds 3 and 2 (each within the scatter of the next).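

At this place on the outer benzene ring, ortho to a large group, this assay gives a number 0.10 log units lower from compound 1 to compound 4 (within the scatter) for the change from 2-ethoxyphenyl to 2-chlorophenyl. Ethoxy, with 3 heavy atoms and 1 hydrogen-bond acceptor, and chloro, with 1 heavy atom and no hydrogen-bond acceptor, therefore cannot be told apart on this number, at least with the side chain of compound 1 in place. Nothing shown here offers a reason for this result.

From the compounds shown here alone, whether a fluoro, a methoxy or a longer chain such as propoxy at this place would also stay within the scatter of compound 1 remains open. The compounds shown also leave open whether chloro would behave the same way alongside the 1-carbamoylpentyl side chain of compound 2.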